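A Shorter Amine Tail on the Shared Core

This account rests on a few compounds, and the source may have more. Where it says the series, first, only, none or still open, it means among the compounds named here.

Compound 1, drawn as `CCCCNCCCCOc1c(O)cc(O)c2c(=O)cc(-c3ccccc3)oc12`, carries a hydroxylated core with a (butylamino)methyl-bearing chain on its ether oxygen. In a functional assay on A549 cells (Homo sapiens) for cytotoxicity, read by MTT assay, with a stated time of 48 h (on this read-out lower numbers stand for stronger inhibition and higher numbers for weaker inhibition), compound 1 has no number to stand on, its entry being "not determined" (no result reported). Within the data shown here, the only number here belongs to compound 2, `CCN(CC)CCCOc1cc(O)c2c(=O)cc(-c3ccccc3)oc2c1OC`, which has a methoxy group on the core and a diethylamino-tipped chain; in this assay compound 2 gives 1830 nM. Compound 3, `COc1c(O)cc(O)c2c(=O)cc(-c3ccc(F)cc3Br)oc12`, has halogens on its pendant phenyl ring and likewise lacks a result: in this assay compound 3 stands at "not determined" (no result reported).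

Compound 4, `CN(C)CCCOc1c(O)cc(O)c2c(=O)cc(-c3ccccc3)oc12`, differs from compound 1 in one place: dimethylamino in place of (butylamino)methyl on a saturated chain carbon, three bonds along the chain from an oxygen on an aromatic ring. Since neither compound 1 nor any single-change pair supplies a measured step, the size of this step in this assay cannot be taken from data; the change is expected to move the value by no more than the usual scatter in either direction. Drawing on compound 2 with its 1830 nM as the nearest measured relative, compound 4 is expected to give about 2000 nM, within a range of 600 nM to 7000 nM.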

Compound 4, half-maximal inhibitory concentration: > 100000 nM
Compound 4: no number, only a limit (the forecaster's own chance of this, stated with the estimate: 20%); at least 50-fold (1.69 log units) between middle value and limit.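

No step can be read from compound 1 to compound 4: compound 1 has no result in this assay. Compound 4 gives > 100000 nM there, a limit and not a number. The compounds shown leave open how much changing the amine tail alone shifts this read-out.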